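Swapping Formyl for Methyl on the Shared Core

The compounds below may be only part of what the source reports. "The series", "measured", "known", "first", "only" and "open" are said of these compounds alone.

Compound 1: `CCCc1c(O)c(C=O)c(C=O)c(O)c1CCC`; -3%
Compound 2: `Cc1c(C)c(O)c(C=O)c(C=O)c1O`; -4%

Of the compounds shown here, two have been tested in a functional assay on the whole organism with Mus musculus as the target, at a dose of 20 mg/kg; on this read-out higher numbers stand for a weaker effect at the one dose given and lower numbers for a stronger effect. Compound 1, `CCCc1c(O)c(C=O)c(C=O)c(O)c1CCC`, gives -3% in this assay. Compound 2, `Cc1c(C)c(O)c(C=O)c(C=O)c1O`, gives -4% in this assay, the lowest of the two numbers, though its gap to compound 1 lies within the scatter, so the two cannot be told apart. Compound 3, `Cc1c(C)c(O)c(C=O)c(C)c1O`, is not yet measured; it differs from compound 2 by methyl in place of formyl on an aromatic carbon. Within the data shown here, with no measured step of this kind to lean on, the expected change in this assay is a number 4 percentage points higher from compound 2 to compound 3 (within the scatter), none beyond the scatter. Compound 3 is therefore estimated at 0%, in the range -15% to 15%.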

Compound 3, a percentage reported as activity, at one dose (the size of the read-out at that dose, not a potency): 25%
Compound 3: the middle estimate sits 25 percentage points below what was measured, and the stated range ends below it.
By their numbers in this assay, from the lowest: compounds 2 and 1 (each within the scatter of the next); then compound 3.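

In this assay, methyl in place of formyl on this aromatic carbon gives a number 29 percentage points higher from compound 2 to compound 3 (beyond the scatter), so what sits at this position does affect the read-out, with the effect at the one dose weaker once this formyl group is gone. The earlier compounds shown here could not show this, as no measured pair differed in one place. Nothing measured here explains why the step occurs. Still open, from the compounds shown here alone, is how a carboxylic acid or an amine on this carbon would read, and whether the same swap would give a similar step on the core of compound 1.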